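Swapping methoxy for a selenium chain on a quinoline

The source may report more compounds than this note shows. Statements on the series, on what has been measured and on what is new or still open speak of the compounds shown alone.

Of the compounds shown here, three sharing one core have been tested in a functional assay on P388 cells (Mus musculus) for cytotoxicity, read by MTT assay, with a stated time of 72 h; on this read-out lower numbers stand for stronger inhibition and higher numbers for weaker inhibition. Compound 1 `OCC#CCSc1cnc2ccccc2c1[Se]CC#CCBr` gives 1.6 ug/mL. Compound 2 `CSc1c(SCC#CCO)cnc2ccccc12` gives 32.3 ug/mL, and compound 3 `COc1c(SCC#CCO)cnc2ccccc12` gives 23.2 ug/mL. On these numbers compound 3 stands second highest of the three: its nearest neighbour is compound 2, since a 1.4-fold lower number from compound 2 to compound 3 (0.14 log units; within the scatter), and its furthest is compound 1, since a 15-fold higher number from compound 1 to compound 3 (1.16 log units; beyond the scatter). The sister step a 20-fold higher number from compound 1 to compound 2 (1.31 log units; beyond the scatter) tells the same story, so replacing the large selenium- and bromine-containing group of compound 1 with a small two-atom group costs a lot of activity in both cases, and the two small groups behave alike.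

Compound 4 `C#CC[Se]c1c(SCC#CCO)cnc2ccccc12` is not yet measured. It differs from compound 3 in one place: a group of 4 heavy atoms (3 carbon, 1 selenium; no ring) in place of a group of 2 heavy atoms (1 carbon, 1 oxygen; no ring), on an aromatic carbon. The entering group brings back selenium and a chain with a triple bond, moving the structure part of the way toward compound 1 without the bromine. Because the steps of a 15-fold higher number from compound 1 to compound 3 (1.16 log units; beyond the scatter) and a 20-fold higher number from compound 1 to compound 2 (1.31 log units; beyond the scatter) were both large when such a group was lost, its partial return is expected to lower the number, though perhaps not all the way. The expected step is a 4.6-fold lower number from compound 3 to compound 4 (0.67 log units; beyond the scatter), giving compound 4 an estimated 5 ug/mL, within a range from 1.5 ug/mL to 16 ug/mL.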

Compound 4, concentration for 50% inhibition: 2.5 ug/mL
Compound 4: the middle estimate sits 2.0-fold (0.30 log units) above what was measured; low and high end bracket the measured number.
By their numbers in this assay, from the lowest: compounds 1 and 4 (each within the scatter of the next); then compounds 3 and 2 (each within the scatter of the next).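

In this assay, the chain of selenium and three carbons with its triple bond, placed on this aromatic carbon opposite the ring nitrogen, makes a clear difference against either small group: in place of methoxy it gives a step beyond the scatter (a 9.3-fold lower number from compound 3 to compound 4 (0.97 log units; beyond the scatter)), and in place of methylsulfanyl a large one (a 13-fold lower number from compound 2 to compound 4 (1.11 log units; beyond the scatter)). Compound 4 also tests the far end of that chain, where hydrogen stands in place of bromomethyl on a triple-bonded carbon, and this change stays within the scatter (a 1.6-fold higher number from compound 1 to compound 4 (0.19 log units; within the scatter)), so among these compounds the low number of compound 1 does not rest on the bromomethyl end. No data here bear on why the selenium chain has this effect.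

Going by these compounds, what stays open is whether the selenium atom or the triple-bonded chain carries the gain, a question that a sulfur atom bearing the same chain, or a selenium atom bearing a plain methyl group, could separate. On these data alone, how this position would respond to a longer chain or to an amine also remains open.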